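Swapping the fluorobenzyl arm for a cyanobenzyl arm

The compounds below may be only part of what the source reports. "The series", "measured", "known", "first", "only" and "open" are said of these compounds alone.

Within the data shown here, compound 2, `O=c1ccoc2cc(OCc3cn(Cc4ccccc4F)nn3)ccc12`, is the only compound with a measured number in a functional assay on SW480 cells (Homo sapiens) for cytotoxicity, read by MTT assay, with a stated time of 48 h; on this read-out higher numbers stand for weaker inhibition and lower numbers for stronger inhibition: compound 2 gives 11400 nM. Compound 1, `O=c1ccoc2cc(OCc3cn(Cc4cccc(F)c4)nn3)ccc12`, reached only (the limit of > 100000 nM in this assay, at which 1 of the 2 values shown sits); in this assay compound 1 gives > 100000 nM, which is a limit of the assay and not a number.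

Compound 3, `N#Cc1cccc(Cn2cc(COc3ccc4c(=O)ccoc4c3)nn2)c1`, differs from compound 2 in one place: 3-cyanophenyl in place of 2-fluorophenyl on a saturated chain carbon bound to an aromatic nitrogen. A single measured step bears on this change, an at least 8.7-fold lower number from compound 1 to compound 2 (0.94 log units; beyond the scatter). Compound 3 carries a 3-cyanophenyl where compound 1 carried a 3-fluorophenyl, and compound 1 sat at the limit, so a higher number than for compound 2 is expected, with the step estimated as a 5.3-fold higher number from compound 2 to compound 3 (0.72 log units; beyond the scatter). For compound 3 the expected value in this assay is 60000 nM, within a range from 15000 nM to 200000 nM.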

Compound 3, half-maximal inhibitory concentration: > 100000 nM
Compound 3 ended at the assay's limit (the forecaster's own chance of this, stated with the estimate: 40%); middle value at least 1.6-fold (0.22 log units) from the limit.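

In this assay, replacing 2-fluorobenzyl with 3-cyanobenzyl gives an at least 8.7-fold higher number from compound 2 to compound 3 (0.94 log units; beyond the scatter), so the activity of compound 2 is lost with this swap. Compound 3 stands at a limit of the assay and not at a number, so this step gives only a minimum size, and the step between compound 1 and compound 3 cannot be read. The 3-fluorophenyl and 3-cyanophenyl arms both end at that limit, while the only number shown belongs to the 2-fluorophenyl arm of compound 2: the limit of > 100000 nM in this assay, at which 2 of the 3 values shown sit.

The swap changes both the group and its printed ring number, so the compounds shown leave open which of the two matters. A 2-cyanobenzyl arm would separate them, and a 2-chlorobenzyl or 2-aminobenzyl arm would show whether anything other than fluoro is tolerated at that ring number.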